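The source may report more compounds than this note shows. Statements on the series, on what has been measured and on what is new or still open speak of the compounds shown alone.

Compound 1 `O=C(CCCc1ccccc1)Nc1nc2ccccc2c(=O)s1`: > 1000 nM in an assay on CHO cells for displacement of a labelled ligand from adenosine receptor A2b (Homo sapiens), read by scintillation counting, with a stated time of 75 min; on this read-out higher numbers stand for weaker inhibition and lower numbers for stronger inhibition
Compound 2 `O=C(C/C=C/c1ccccc1)Nc1nc2ccccc2c(=O)s1`: 119 nM

In this assay compound 1 gives only a limit, (the limit of > 1000 nM in this assay, at which 1 of the 2 values shown sits), and not a number. Within the data shown here, compound 2 is therefore the one compound here with a measured number. Compound 3 `O=C(C/C=C/c1ccc(Cl)c(Cl)c1)Nc1nc2ccccc2c(=O)s1` differs from compound 2 by 3,4-dichlorophenyl in place of phenyl on a double-bonded chain carbon bound to a double-bonded chain carbon. Among the measured compounds shown here, since no step between two measured compounds is available, the effect of this change is unknown, and a shift of compound 3 from compound 2 no larger than the usual scatter in this assay is expected. The step expected from compound 2 to compound 3 is a 1.5-fold lower number from compound 2 to compound 3 (0.17 log units; within the scatter), giving compound 3 an estimated 80 nM, between 30 nM and 300 nM.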

Compound 3, inhibition constant: > 1000 nM
Compound 3: only a limit was reported (the forecaster's own chance of this, stated with the estimate: 5%); middle value at least 12-fold (1.09 log units) away from the limit.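

On this double-bonded chain carbon, the ring substituents matter: in this assay, 3,4-dichlorophenyl in place of phenyl gives an at least 8.4-fold higher number from compound 2 to compound 3 (0.92 log units; beyond the scatter), so the two added chlorine atoms weaken inhibition rather than leaving it unchanged. Compound 3 gives only a limit, so this step marks a minimum and its full size cannot be read: the limit of > 1000 nM in this assay, at which 2 of the 3 values shown sit. The compounds shown leave open whether a single chlorine at either ring position would weaken inhibition as much. They also leave open how a fluorine or a methoxy group on the phenyl ring would compare.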